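The source may hold more compounds than are shown below. What is called first, only, known or untested is meant among the compounds shown, and "the series" means these compounds.

Measured in an assay on urine for inhibition of Myeloperoxidase (Homo sapiens); on this read-out lower numbers stand for stronger inhibition and higher numbers for weaker inhibition:
compound 1 `NCc1c[nH]c2ccc(F)cc12` — 900 nM
compound 2 `CCN(CC)Cc1c[nH]c2ccc(F)cc12` — 200 nM
compound 3 `CNCCCc1c[nH]c2ccc(F)cc12` — 200 nM

Compound 3 sits level with compound 2 at the digits reported; together they give the lowest numbers of the three. Within the data shown here, its only neighbour beyond the scatter is compound 1: a 4.5-fold lower number from compound 1 to compound 3 (0.65 log units; beyond the scatter). The parallel step to compound 2 reads a 4.5-fold lower number from compound 1 to compound 2 (0.65 log units; beyond the scatter), while the two alkylated amines differ by nothing at the digits reported: no change at the digits printed from compound 2 to compound 3 (within the scatter).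

Compound 4 `CCCNCCCc1c[nH]c2ccc(F)cc12` carries ethyl in place of hydrogen on a saturated chain carbon bound to an amine nitrogen, so the methylamino end of compound 3 becomes propylamino.

The measured steps that bear on this are both changes at the basic nitrogen. Adding carbon there once moved the number down, from compound 1 to compound 2 and from compound 1 to compound 3; but between compound 2 and compound 3, which differ in how the nitrogen is substituted, nothing beyond the scatter appears. Since compound 3 already carries an alkylated nitrogen, the closer precedent is no change at the digits printed from compound 2 to compound 3 (within the scatter), so the expected step of a 1.3-fold lower number from compound 3 to compound 4 (0.12 log units; within the scatter) is small, perhaps not beyond the scatter, leaning if anywhere toward a lower number.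

For compound 4 in this assay the estimate is 150 nM, within 60 nM to 400 nM.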

Compound 4, half-maximal inhibitory concentration: 170 nM
The estimate for compound 4 lay 1.1-fold (0.05 log units) below the measured number, within the range that was stated.
By their numbers in this assay, from the lowest: compounds 4, 2 and 3 (each within the scatter of the next); then compound 1.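

In this assay, the methylamino end of compound 3 becomes propylamino with the rest of the molecule unchanged, and the result is a 1.2-fold lower number from compound 3 to compound 4 (0.07 log units; within the scatter). Among these compounds, this is the first step that alters only the length of the alkyl group on a secondary amine nitrogen, and it shows that ethyl in place of hydrogen on a saturated chain carbon bound to an amine nitrogen is tolerated in this assay, with no gain or loss that can be told from the scatter; the size of a 4.5-fold lower number from compound 1 to compound 3 (0.65 log units; beyond the scatter) is not repeated by this further addition of carbon. Nothing measured here accounts for this flat response, so it stands as an observation only.

From the compounds shown here alone, whether the flat response continues further out remains open: a butyl or benzyl group on the nitrogen, or a carboxylic acid at the end of the propyl group, could still shift the number in either direction. Also open, going by these compounds, is whether a longer chain carrying the amine, or a piperidine in place of the open-chain amine, would keep the number in the same range.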